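Swapping the silicon-bound ring's substituent in squalene monooxygenase inhibitors

The compounds below may be only part of what the source reports. "The series", "measured", "known", "first", "only" and "open" are said of these compounds alone.

Measured compounds:
compound 1 `CCN(C/C=C/C#CC(C)(C)C)Cc1cccc(OC[Si](C)(C)c2ccc(Br)cc2)c1`, 210 nM
compound 2 `CCN(C/C=C/C#CC(C)(C)C)Cc1cccc(OC[Si](C)(C)c2cccc(C)c2)c1`, 3000 nM

In a functional assay on liver (Sus scrofa) for inhibition of squalene monooxygenase (Homo sapiens), using microsomes (on this read-out higher numbers stand for weaker inhibition and lower numbers for stronger inhibition), compound 2 stands with the highest of the two numbers; its nearest neighbour is compound 1, and a 14-fold higher number from compound 1 to compound 2 (1.15 log units; beyond the scatter). Compound 3 `CCN(C/C=C/C#CC(C)(C)C)Cc1cccc(OC[Si](C)(C)c2ccc(S)cc2)c1` is not yet measured and differs from compound 2 in one place: 4-sulfanylphenyl in place of 3-methylphenyl on a silicon. Within the data shown here, the only measured step, a 14-fold higher number from compound 1 to compound 2 (1.15 log units; beyond the scatter), shows that the substituent on this ring can move the number strongly. For compound 3 a lower number than compound 2 is expected, a 5.0-fold lower number from compound 2 to compound 3 (0.70 log units; beyond the scatter), placing the estimate at 600 nM with a range from 150 nM to 2500 nM.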

Compound 3, half-maximal inhibitory concentration: 8000 nM
Beside the measured number, compound 3's estimate is 13-fold (1.12 log units) below it; the measured number lies above the stated range.
By their numbers in this assay, from the lowest: compound 1; then compound 2; then compound 3.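

In this assay the 4-sulfanylphenyl ring gives a 2.7-fold higher number from compound 2 to compound 3 (0.43 log units; beyond the scatter) and sulfanyl in place of bromo gives a 38-fold higher number from compound 1 to compound 3 (1.58 log units; beyond the scatter) with the rest of the molecule unchanged. A group in the 4 position therefore does not guarantee a low number, since 4-bromophenyl and 4-sulfanylphenyl end up far apart. Nothing available explains this gap and the reason stays unknown.

The compounds shown leave open how 4-chlorophenyl, 4-methoxyphenyl or unsubstituted phenyl would compare. A 4-methylphenyl ring would also help separate the effect of the group from that of its place on the ring.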